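Propanoyl to isopropylcarbonyl on the shared core

The compounds below may be only part of what the source reports. "The series", "measured", "known", "first", "only" and "open" are said of these compounds alone.

Measured so far:
compound 1 `Cc1c(OCCCCOc2ccccc2C(=O)O)ccc(C(=O)CC2CCCC2)c1O` — "not determined" (no result reported) in an assay on HEK293 cells for positive allosteric modulation of metabotropic glutamate receptor 3 (Rattus norvegicus), read by thallium flux, with a stated time of 2.5 min; a higher number here means that more compound is needed for the effect, a lower number that less compound is needed
compound 2 `Cc1c(OCCCCOc2ccc(C(=O)O)cc2F)ccc(C(=O)CC(C)C)c1O` — 1420 nM in this assay
compound 3 `CCC(=O)c1ccc(OCCCCOc2cc(C(=O)O)ccc2OC)c(C)c1O` — 6360 nM in this assay

Compound 3 stands at the highest of the two numbers in hand. Its nearest neighbour is compound 2, whose number is lower by a gap that is beyond the scatter; compound 1 contributes no number. Going by the values given here, the two measured compounds differ at several places at once, so no single step between them can be read.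

Compound 4 `COc1ccc(C(=O)O)cc1OCCCCOc1ccc(C(=O)C(C)C)c(O)c1C` is the next entry. Against compound 3 it shows (methyl in place of hydrogen on a saturated chain carbon bound to a carbonyl carbon and a saturated chain carbon). Among the compounds with values here, no step of this kind is present among the measured compounds, so the expectation rests on compound 3 alone: a small move towards a lower number, of a size that may not clear the scatter, is estimated as a 1.7-fold lower number from compound 3 to compound 4 (0.22 log units; within the scatter). On that basis compound 4 is expected to give 3800 nM in this assay, with a range from 1300 nM to 11000 nM.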

Compound 4, half-maximal effective concentration: 588 nM
Compound 4: middle estimate off by 6.5-fold (0.81 log units), on the high side; measured number below the stated range.
By their numbers in this assay, from the lowest: compound 4; then compound 2; then compound 3.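

Methyl in place of hydrogen on a saturated chain carbon bound to a carbonyl carbon and a saturated chain carbon, the change from propanoyl to isopropylcarbonyl, gives the first step of the series that can be read in this assay: an 11-fold lower number from compound 3 to compound 4 (1.03 log units; beyond the scatter). Going by these compounds alone, the number at this position therefore responds strongly to this one added carbon with the rest of the shared core unchanged, which the earlier compounds, differing at several places at once, could not show. Nothing measured here accounts for the size of this step.

From the compounds shown here alone, whether the number falls further with tert-butylcarbonyl or cyclopropylcarbonyl at this position remains open. Within the data shown here, also open is whether a step of this size carries over to a core other than the one shared by compound 3 and compound 4.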